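A few compounds are considered here, and "the series" means these few. Any claim that something is new, unique, unknown or untested is made for them only; others in the source may bear on it.

Going by the values given here, compound 2 `CNC(=O)c1cc(Oc2ccc(NC(=O)c3cc4cccnc4n(-c4ccc(OC)cc4)c3=O)cc2)ccn1` shows the lower of the two numbers so far in a functional assay on HT-29 cells (Homo sapiens) for antiproliferative activity, read by MTT assay, with a stated time of 72 h (on this read-out lower numbers stand for stronger inhibition and higher numbers for weaker inhibition), giving 920 nM, while compound 1 `CNC(=O)c1cc(Oc2ccc(NC(=O)c3cc4cccnc4n(-c4ccc(Br)cc4)c3=O)cc2)ccn1` gives 1180 nM; that difference, a 1.3-fold lower number from compound 1 to compound 2 (0.11 log units; within the scatter), lies within the scatter. Compound 3 `CCCNC(=O)c1cc(Oc2ccc(NC(=O)c3cc4cccnc4n(-c4ccc(OC)cc4)c3=O)cc2)ccn1` differs from compound 2 by ethyl in place of hydrogen on a saturated chain carbon bound to an amide-type nitrogen, methylcarbamoyl becoming propylcarbamoyl. Among the compounds with values here, the only measured step changed a different place, the aromatic carbon, and so does not bear on this lengthening; no measured step covers it. Compound 3 is therefore expected to show, relative to its parent, a 1.1-fold higher number from compound 2 to compound 3 (0.04 log units; within the scatter) in this assay, nothing beyond the scatter. Compound 3 is estimated at 1000 nM, between 400 nM and 2500 nM.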

Compound 3, half-maximal inhibitory concentration: 1560 nM
Compound 3: middle estimate off by 1.6-fold (0.19 log units), on the low side; the measured number falls inside the stated range.
By their numbers in this assay, from the lowest: compounds 2, 1 and 3 (each within the scatter of the next).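

Going from methylcarbamoyl to propylcarbamoyl gives a 1.7-fold higher number from compound 2 to compound 3 (0.23 log units; within the scatter) in this assay. Going by these compounds alone, this is the first measured change at this place, and it shows that ethyl in place of hydrogen on this chain carbon leaves the two numbers within the scatter of each other. Nothing measured here offers an explanation for this result.

As far as these compounds go, whether a longer chain, or a chain carrying an amine or a carboxylic acid, would move the number beyond the scatter remains open. So does whether propylcarbamoyl behaves the same way with bromo in place of methoxy.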